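The source may report more compounds than this note shows. Statements on the series, on what has been measured and on what is new or still open speak of the compounds shown alone.

In an ADME assay on microsomes from liver (Homo sapiens) for metabolic stability, read by LC-MS, using NADPH, with a stated time of 10 min, tested at 10 uM (a lower number here means that the compound disappears faster, a higher number that the compound lasts longer), compound 1 `CC(C)(C)n1nc(Oc2cc(O)ccn2)c2c(N)ncnc21` gives 1.4 h. Compound 2 `CO[C@H]1CC[C@H](n2nc(Oc3cc(C(F)(F)F)ccn3)c3c(N)ncnc32)CC1` reaches only a limit of this assay, > 2.41 h, so its true half-life is not known as a number; (the limit of > 2.41 h in this assay, at which 1 of the 2 values shown sits). Compound 3 `Nc1ncnc2c1c(Oc1cc(C(F)(F)F)ccn1)nn2C1CCCC1` has not yet been measured in this assay. It differs from compound 2 in one place: cyclopentyl in place of 4-methoxycyclohexyl on an aromatic nitrogen. Among the measured compounds shown here, no measured pair here shares this change, so its effect is open; a step of modest size is expected, most likely downward or within the scatter. Compound 3 is therefore estimated at 2 h, between 1 h and 4 h, which would mean an expected step of an at least 1.2-fold lower number from compound 2 to compound 3 (0.08 log units; that floor lies within the scatter).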

Compound 3, half-life: 0.333 h
For compound 3 the middle estimate is 6.0-fold (0.78 log units) above the measured one, outside the stated range (below it).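

In this assay, cyclopentyl in place of 4-methoxycyclohexyl on an aromatic nitrogen brings an at least 7.2-fold lower number from compound 2 to compound 3 (0.85 log units; beyond the scatter). This shows that the group at this position bears strongly on the half-life, which compound 1 and compound 2, differing in more than one place, could not show. The full size of the step remains unknown because compound 2 stands at a limit: the limit of > 2.41 h in this assay, at which 1 of the 3 values shown sits.

The compounds shown leave open whether the drop follows the ring size or the methoxy group, since both change together. A plain cyclohexyl on this nitrogen would separate the two.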